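Swapping fluoro for trifluoromethyl on the aryl ring

The compounds below may be only part of what the source reports. "The series", "measured", "known", "first", "only" and "open" are said of these compounds alone.

Measured so far:
compound 1, `Cn1ccc2c(Oc3ccc(NC(=O)c4nn(-c5ccc(Cl)c(C(F)(F)F)c5)ccc4=O)cc3)ccnc21`, 23400 nM
compound 2, `Cn1ccc2c(Oc3ccc(NC(=O)c4nn(-c5ccc(Br)cc5)ccc4=O)cc3F)ccnc21`, > 60000 nM
compound 3, `Cn1ccc2c(Oc3ccc(NC(=O)c4nn(-c5ccc(Cl)c(F)c5)ccc4=O)cc3F)ccnc21`, 22100 nM

Of the compounds shown here, three sharing one core have been tested in a functional assay on HepG2 cells (Homo sapiens) for cytotoxicity, read by MTT assay, with a stated time of 72 h; a higher number here means a weaker inhibitor, a lower number a stronger inhibitor. Compound 1 gives 23400 nM. For compound 2 the assay reports only a limit, > 60000 nM, and not a number. Compound 3 gives 22100 nM, the lowest of the two numbers shown, though compound 1 sits within the scatter of it. Within the data shown here, the only single-point step among the measured compounds is an at least 2.7-fold lower number from compound 2 to compound 3 (0.43 log units; beyond the scatter), which rests on the limit of > 60000 nM in this assay, at which 1 of the 3 values shown sits, for compound 2.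

Compound 4, `Cn1ccc2c(Oc3ccc(NC(=O)c4nn(-c5ccc(Cl)c(C(F)(F)F)c5)ccc4=O)cc3F)ccnc21`, has not yet been measured. It differs from compound 3 by trifluoromethyl in place of fluoro on an aromatic carbon, placed ortho to a chloro group and meta to a large group. Among the measured compounds shown here, no measured step covers this exchange directly. Compound 1 carries the same 4-chloro-3-(trifluoromethyl)phenyl group and gives 23400 nM, and compound 3 gives 22100 nM, two numbers within the scatter of one another. The expected step is therefore a 1.0-fold lower number from compound 3 to compound 4 (0.00 log units; within the scatter), no change beyond the scatter. Compound 4 is estimated at 22000 nM, with a range from 10000 nM to 50000 nM.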

Compound 4, half-maximal inhibitory concentration: 13500 nM
Beside the measured number, compound 4's estimate is 1.6-fold (0.21 log units) above it; the measured number falls inside the stated range.
By their numbers in this assay, from the lowest: compounds 4, 3 and 1 (each within the scatter of the next). At a limit, above all of these: compound 2.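

In this assay, the exchange at this position, ortho to a chloro group, now has a direct reading: a 1.6-fold lower number from compound 3 to compound 4 (0.21 log units; within the scatter), so trifluoromethyl, with its 4 heavy atoms, and fluoro, with its 1, cannot be told apart here. The fluoro added elsewhere on the molecule gives the same kind of result, a 1.7-fold lower number from compound 1 to compound 4 (0.24 log units; within the scatter), so compound 1 and compound 4 cannot be told apart either, and neither single change separates compound 4 from its closest relatives. The only new step beyond the scatter, an at least 4.4-fold lower number from compound 2 to compound 4 (0.64 log units; beyond the scatter), replaces the whole 4-bromophenyl group and starts from a limit, not a number: the limit of > 60000 nM in this assay, at which 1 of the 4 values shown sits.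

From the compounds shown here alone, whether an amine or a carboxylic acid at this position, with the chloro group kept, would shift the number beyond the scatter remains open. Also open, going by these compounds, is how the 4-chloro-3-fluorophenyl group would read on the core of compound 1, which lacks the second fluoro, and so whether the exchange behaves the same way there.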